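From 4-Methylphenyl to 3-Bromophenyl on the Amide

The source may report more compounds than this note shows. Statements on the series, on what has been measured and on what is new or still open speak of the compounds shown alone.

Compounds in a functional assay on A549 cells (Homo sapiens) for inhibition, read by CCK-8 assay, with a stated time of 72 h, tested at 1 uM; on this read-out higher numbers stand for more inhibition of growth at the one concentration tested and lower numbers for less inhibition of growth:
Compound 1 `CN(C)C(=O)c1cc2cnc(Nc3ccc(NC(=O)C4(C(=O)Nc5ccc(Cl)cc5)CC4)cc3)nc2n1C1CCCC1`: 24.7%
Compound 2 `Cc1ccc(NC(=O)C2(C(=O)Nc3ccc(Nc4ncc5cc(C(=O)N(C)C)n(C6CCCC6)c5n4)cc3)CC2)cc1`: 40.2%
Compound 3 `CN(C)C(=O)c1cc2cnc(Nc3ccc(NC(=O)C4(C(=O)Nc5cccc(Br)c5)CC4)cc3)nc2n1C1CCCC1`: not yet measured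

Compound 2 stands highest of the two measured compounds in this assay at 40.2%, while compound 1 reaches 24.7%. Compound 3 keeps the shared core but changes the group on the amide: 3-bromophenyl in place of 4-methylphenyl on an amide-type nitrogen. In short, 3-bromophenyl takes the place of 4-methylphenyl on an amide-type nitrogen.

Going by the values given here, only one measured step bears on this change: a number 15.5 percentage points higher from compound 1 to compound 2 (beyond the scatter), with methyl in place of chloro on an aromatic carbon. That step is modest, and it shows the chloro compound 1 as the lower of the pair. Neither measured compound carries bromine or the 3-bromophenyl group, so this guide is only partial. A modest fall is expected, somewhat smaller than the measured step, and the uncertainty is wide.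

The estimated change is a number 9.2 percentage points lower from compound 2 to compound 3 (within the scatter). For compound 3 the expected value is 31%, with an estimated range from 15% to 47%.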

Compound 3, percent growth inhibition at one concentration: 20.2%
For compound 3 the middle estimate is 10.8 percentage points above the measured one; measured number inside the range.
By their numbers in this assay, from the lowest: compounds 3 and 1 (each within the scatter of the next); then compound 2.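

Exchanging 4-methylphenyl for 3-bromophenyl on the amide-type nitrogen gives a number 20 percentage points lower from compound 2 to compound 3 (beyond the scatter) in this assay and shows that this position responds to a change other than the earlier swap of methyl for chloro. The exchange of 4-chlorophenyl for 3-bromophenyl gives a number 4.5 percentage points lower from compound 1 to compound 3 (within the scatter) and leaves the two halogen-bearing compounds without an order, so among these three compounds only the 4-methylphenyl group of compound 2 stands apart, and no compound here goes against that reading. Nothing given here accounts for the gap between compound 2 and the two halogen-bearing compounds.

Still open, as far as these compounds go, is whether the lower number of compound 3 follows the change of methyl to bromine or the change of ring position in the group's name, a question that 3-methylphenyl and 4-bromophenyl on the same nitrogen would separate. Also open, from the compounds shown here alone, is how unsubstituted phenyl, or a phenyl group carrying an amine or a carboxylic acid, would read at this position in this assay.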